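Benzyl variation on the shared core, compound 4 pending

This account rests on a few compounds, and the source may have more. Where it says the series, first, only, none or still open, it means among the compounds named here.

Compound 3 `O=c1ccoc2cc(OCc3cn(Cc4cccc(Cl)c4)nn3)ccc12` stands at a limit in a functional assay on SGC-7901 cells (Homo sapiens) for cytotoxicity, read by MTT assay, with a stated time of 48 h (a lower number here means a stronger inhibitor, a higher number a weaker inhibitor), giving > 100000 nM. Compound 1 `Cc1ccccc1Cn1cc(COc2ccc3c(=O)ccoc3c2)nn1` also sits at a limit in this assay, with > 100000 nM. Compound 2 `O=c1ccoc2cc(OCc3cn(Cc4ccc(Cl)cc4Cl)nn3)ccc12` likewise reaches only a limit, > 100000 nM. The steps a step that the two limits leave unreadable from compound 1 to compound 2, a step that the two limits leave unreadable from compound 1 to compound 3 and a step that the two limits leave unreadable from compound 2 to compound 3 therefore cannot be sized; all three values sit together at the same limit (the limit of > 100000 nM in this assay, at which 3 of the 3 values shown sit). Compound 4 `N#Cc1ccc(Cn2cc(COc3ccc4c(=O)ccoc4c3)nn2)cc1` carries the change (4-cyanophenyl in place of 3-chlorophenyl on a saturated chain carbon bound to an aromatic nitrogen). Among the compounds with values here, no measured step at this position is readable, so no direction can be taken from the series. The estimated step of a number no higher from compound 3 to compound 4 (the limit leaves the size open) is set as none beyond the scatter. Compound 4 is expected at 100000 nM, in the range 30000 nM to 300000 nM, most likely reported again as a limit.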

Compound 4, half-maximal inhibitory concentration: > 100000 nM
Compound 4 was reported as a limit; the forecaster's own chance of this, stated with the estimate: 85%; the middle value sits exactly at the limit.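

In this assay, within the data shown here, compound 4 gives > 100000 nM as a limit, so no step among compound 1, compound 2, compound 3 and compound 4 can be read: the limit of > 100000 nM in this assay, at which 4 of the 4 values shown sit.
Left open in this assay is whether any benzyl group on the shared core gives a readable value.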